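Piperidin-1-yl for pyrrolidin-1-yl on the shared core

This account rests on a few compounds, and the source may have more. Where it says the series, first, only, none or still open, it means among the compounds named here.

compound 1 `CCN(CC)c1cc2nc(-c3ccccc3)nn(-c3ccccc3)c-2cc1=O` with > 5000 nM (a limit, not a number)
compound 2 `O=c1cc2n(-c3ccccc3)nc(-c3ccccc3)nc-2cc1N1CCCC1` with 360 nM

Among the compounds with values here, in a functional assay on MCF7 cells (Homo sapiens) for cytotoxicity, read by MTT assay, with a stated time of 72 h (a higher number here means a weaker inhibitor, a lower number a stronger inhibitor), compound 2 holds the only true number so far. The other value is a limit, that of compound 1 (the limit of > 5000 nM in this assay, at which 1 of the 2 values shown sits). Compound 3 `O=c1cc2n(-c3ccccc3)nc(-c3ccccc3)nc-2cc1N1CCCCC1` differs from compound 2 by piperidin-1-yl in place of pyrrolidin-1-yl on an aromatic carbon ( piperidin-1-yl in place of pyrrolidin-1-yl on an aromatic carbon ). Within the data shown here, one measured step bears on this amine, an at least 13-fold lower number from compound 1 to compound 2 (1.14 log units; beyond the scatter), which was large and replaced diethylamino at the same place. Because of an at least 13-fold lower number from compound 1 to compound 2 (1.14 log units; beyond the scatter) a modest move toward the value of compound 1 is expected, much smaller than that step. The expected change is a 2.2-fold higher number from compound 2 to compound 3 (0.35 log units; beyond the scatter) in this assay, near the edge of the scatter. Compound 3 is estimated at 800 nM ( expected range 300 nM to 2500 nM).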

Compound 3, half-maximal inhibitory concentration: 1980 nM
Estimate against measurement, compound 3: 2.5-fold (0.39 log units) below, within the range that was stated.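

In this assay the position also separates the two cyclic amines, with the six-membered ring of piperidin-1-yl giving a 5.5-fold higher number from compound 2 to compound 3 (0.74 log units; beyond the scatter), so pyrrolidin-1-yl is the best of the three groups shown. Piperidin-1-yl still improves on diethylamino, with an at least 2.5-fold lower number from compound 1 to compound 3 (0.40 log units; beyond the scatter). This last step rests on the value of compound 1, which is a limit and not a number: the limit of > 5000 nM in this assay, at which 1 of the 3 values shown sits.

On these data alone, whether the rise continues with azepan-1-yl on the same aromatic carbon remains open. So does whether morpholin-4-yl stays near compound 2 or near compound 3.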